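Reshaping the Six-Carbon Group on the Double-Bonded Nitrogen

The compounds below may be only part of what the source reports. "The series", "measured", "known", "first", "only" and "open" are said of these compounds alone.

Compound 3 `CC(C)C(C)(C)/N=C(\NC#N)Nc1cccnc1` is one of three measured analogues built on a shared core. In a functional assay on the whole organism (blood, strain Wistar-Okamoto) with Rattus norvegicus as the target, with a stated time of 5 days (a higher number here means that more compound is needed for the effect, a lower number that less compound is needed), compound 3 gives 1 mg/kg, level with compound 2 `CCCC(C)(C)/N=C(\NC#N)Nc1cccnc1`, which gives 1 mg/kg; together these are the lowest numbers of the set. Compound 1 `CCC(CC)/N=C(\NC#N)Nc1cccnc1` gives 20 mg/kg, and a 20-fold lower number from compound 1 to compound 3 (1.30 log units; beyond the scatter). Compound 4 `CCC(C)(CC)/N=C(\NC#N)Nc1cccnc1` remains unmeasured; (1-ethyl-1-methylpropyl in place of 1,1,2-trimethylpropyl on a double-bonded nitrogen). Within the data shown here, the steps that bear on this change are a 20-fold lower number from compound 1 to compound 2 (1.30 log units; beyond the scatter) and a 20-fold lower number from compound 1 to compound 3 (1.30 log units; beyond the scatter), both large, whereas no change at the digits printed from compound 2 to compound 3 (within the scatter). Because no change at the digits printed from compound 2 to compound 3 (within the scatter) between two groups of the same size, a further exchange of one six-carbon group for another is expected to stay within the scatter. Compound 4 is therefore expected to show no change at the digits printed from compound 3 to compound 4 (within the scatter), with an estimate of 1 mg/kg and a range from 0.5 mg/kg to 2 mg/kg.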

Compound 4, minimum effective dose: 0.5 mg/kg
The estimate for compound 4 lay 2.0-fold (0.30 log units) above the measured number; low and high end bracket the measured number.
By their numbers in this assay, from the lowest: compounds 4, 2 and 3 (each within the scatter of the next); then compound 1.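

In this assay, a third arrangement of the six-carbon group on the double-bonded nitrogen stays level with the other two (a 2.0-fold lower number from compound 3 to compound 4 (0.30 log units; within the scatter)) and (a 2.0-fold lower number from compound 2 to compound 4 (0.30 log units; within the scatter)). Among these compounds, compound 1 and compound 4 differ by one methyl in place of hydrogen on the saturated chain carbon bound to the double-bonded nitrogen, and this single exchange gives the large step (a 40-fold lower number from compound 1 to compound 4 (1.60 log units; beyond the scatter)), the first direct pair to isolate it.

As far as these compounds go, whether a cyclohexyl group or a longer chain at this position would keep the low number remains open. Nothing shown explains these numbers.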